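Swapping the outer aryl ring in a weak antiproliferative series

The source may hold more compounds than are shown below. What is called first, only, known or untested is meant among the compounds shown, and "the series" means these compounds.

Measured so far:
- compound 1 `COc1ccccc1-c1c(C)nn(-c2nc(-c3ccc(Cl)c(Cl)c3)c(SC(C)C)s2)c1C(=O)O`: 14700 nM
- compound 2 `Cc1c(-c2cc(Cl)cc(Cl)c2)c(C(=O)O)nn1-c1nc(-c2ccc3nccn3c2)c(SC(C)C)s1`: "not active" (no number reported)
- compound 3 `Cc1c(-c2cc(Cl)cc(Cl)c2)c(C(=O)O)nn1-c1nc(-c2cnn(C)c2)c(SC(C)C)s1`: "not active" (no number reported)

These three compounds were tested in a functional assay on BJAB cells (Homo sapiens) for antiproliferative activity, with a stated time of 4 days; a higher number here means that more compound is needed for the effect, a lower number that less compound is needed. Compound 1 is the only one of the three for which a number was obtained, and that number, 14700 nM, is high, so a large amount of compound was needed before cell growth slowed. Compound 2 and compound 3, which carry a different chlorinated phenyl ring on the shared core and different groups on the other side of the molecule, gave no number at all in this assay. Compound 2 was simply recorded as "not active" (no number reported). Compound 3 was likewise recorded as "not active" (no number reported). No pair of these compounds differs in only one place, so no measured step can be drawn from them.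

The next compound, compound 4 `CNc1cc(-c2c(C)nn(-c3nc(-c4ccc(Cl)c(Cl)c4)c(SC(C)C)s3)c2C(=O)O)ccn1`, differs from compound 1 in a single place: 2-(methylamino)pyridin-4-yl in place of 2-methoxyphenyl on an aromatic carbon. Among the measured compounds shown here, nothing among the measured compounds speaks to this exchange, so the expected step in this assay is small, within the scatter or at most a modest gain, with wide uncertainty. Compound 4 is therefore estimated at 8000 nM, in a range from 2000 nM to 30000 nM, which means an expected step of a 1.8-fold lower number from compound 1 to compound 4 (0.26 log units; within the scatter).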

Compound 4, half-maximal effective concentration: 18000 nM
Beside the measured number, compound 4's estimate is 2.3-fold (0.35 log units) below it; the measured number falls inside the stated range.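

In this assay, the step is a 1.2-fold higher number from compound 1 to compound 4 (0.09 log units; within the scatter), so the two compounds cannot be told apart at this position on the shared core. Among the compounds shown here, this is the first measured comparison in which only one place changes, and it shows that a pyridine ring carrying a methylamino group can stand in for 2-methoxyphenyl with no change beyond the scatter, even though the entering group adds a hydrogen-bond donor and ring nitrogen. No measured information on the compounds accounts for this result, so the comparison records the outcome without explaining it.

For the compounds shown here, only two groups of the same heavy-atom count have been compared here, so it remains open whether this position is insensitive to change in general or only to this particular exchange. A much smaller group such as an ethyl chain, or a saturated ring such as morpholine, would test whether the antiproliferative number can move at all from this place.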